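Swapping Methoxy for Methyl on an Aryl Piperazine

This account rests on a few compounds, and the source may have more. Where it says the series, first, only, none or still open, it means among the compounds named here.

Of the compounds shown here, two have been measured in a functional assay for antagonist activity at Adrenergic receptor alpha-1 (Rattus norvegicus); on this read-out lower numbers stand for tighter binding and higher numbers for weaker binding. Compound 1 `COc1ccc(Cl)cc1N1CCN(CCNC(=O)c2cccnc2)CC1` gives 2750 nM, and compound 2 `COc1ccc(N2CCN(CCNC(=O)c3cccnc3)CC2)cc1` gives 1620 nM, the lower of the two numbers, although its gap to compound 1 lies within the scatter. Compound 3 `Cc1ccc(N2CCN(CCNC(=O)c3cccnc3)CC2)cc1` has not been measured; it differs from compound 2 by methyl in place of methoxy on an aromatic carbon. Within the data shown here, no step between measured compounds is available, so the direction of this change cannot be read from the data, and a step no larger than the scatter is expected. For compound 3 the estimate is 2000 nM, with a range of 700 nM to 6000 nM. The step this estimate implies is expected to be a 1.2-fold higher number from compound 2 to compound 3 (0.09 log units; within the scatter).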

Compound 3, dissociation constant: 295 nM
Beside the measured number, compound 3's estimate is 6.8-fold (0.83 log units) above it; measured number outside the range, below it.
By their numbers in this assay, from the lowest: compound 3; then compounds 2 and 1 (each within the scatter of the next).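

In this assay, among these compounds, methyl in place of methoxy on this aromatic carbon, para to a large group, gives a 5.5-fold lower number from compound 2 to compound 3 (0.74 log units; beyond the scatter), the first single-change comparison here. It shows that the number responds to what sits at this position, and that removing the oxygen of methoxy here goes with a tighter reading. Nothing available explains the size of this step. From the compounds shown here alone, whether ethyl, fluorine or an amine at the same place would lower the number further stays open. So does whether the same swap would carry over to the core of compound 1.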